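Taking the fluoro off compound 3

The source may report more compounds than this note shows. Statements on the series, on what has been measured and on what is new or still open speak of the compounds shown alone.

Measured in a functional assay on A2780 cells (Homo sapiens) for antiproliferative activity, read by fluorescence, with a stated time of 72 h; a higher number here means a weaker inhibitor, a lower number a stronger inhibitor:
- Compound 1 `CN1CCC(C(=O)N2Cc3c(NC(=O)c4cccs4)n[nH]c3C2(C)C)CC1`: 30 nM
- Compound 2 `CN1CCC(C(=O)N2Cc3c(NC(=O)c4ccncc4)n[nH]c3C2(C)C)CC1`: 500 nM
- Compound 3 `CN1CCC(C(=O)N2Cc3c(NC(=O)c4cccc(F)c4)n[nH]c3C2(C)C)CC1`: 200 nM

Compound 3 holds the middle of the three numbers, with a 2.5-fold lower number from compound 2 to compound 3 (0.40 log units; beyond the scatter) and a 6.7-fold higher number from compound 1 to compound 3 (0.82 log units; beyond the scatter) marking its distance from the other two. Compound 4 `CN1CCC(C(=O)N2Cc3c(NC(=O)c4ccccc4)n[nH]c3C2(C)C)CC1` carries hydrogen in place of fluoro on an aromatic carbon. For the measured compounds named here, no measured step makes this exact change. The nearest ones exchange the whole group on the carbonyl carbon, and they reach from the modest 2.5-fold lower number from compound 2 to compound 3 (0.40 log units; beyond the scatter) to the large 17-fold higher number from compound 1 to compound 2 (1.22 log units; beyond the scatter). Removing one fluoro is a far smaller edit, so no step beyond the scatter is expected in this assay. The estimated step is a 1.2-fold lower number from compound 3 to compound 4 (0.07 log units; within the scatter). Compound 4 is expected at 170 nM, within an estimated range of 70 nM to 420 nM.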

Compound 4, half-maximal inhibitory concentration in the A2780 assay: 160 nM
Estimate against measurement, compound 4: 1.1-fold (0.03 log units) above; the range from low to high includes it.
By their numbers in the A2780 assay, from the lowest: compound 1; then compounds 4 and 3 (each within the scatter of the next); then compound 2.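

In the A2780 assay, exchanging fluoro for hydrogen on this aromatic carbon leaves the read-out within the scatter, with a 1.3-fold lower number from compound 3 to compound 4 (0.10 log units; within the scatter). The plain phenyl also shows that the gaps to the other carbonyl groups in the A2780 assay do not depend on the fluoro, with a 3.1-fold lower number from compound 2 to compound 4 (0.49 log units; beyond the scatter) and a 5.3-fold higher number from compound 1 to compound 4 (0.73 log units; beyond the scatter). In a physicochemical assay for solubility, at pH 7 (on this read-out lower numbers stand for lower solubility and higher numbers for higher solubility), compound 3 gives > 225000 nM, which is a limit of the assay. In the physicochemical assay, compound 4 gives > 225000 nM, which is also a limit of the assay. In the physicochemical assay, the step for this change cannot be read, as both values are limits: the limit of > 225000 nM in the physicochemical assay, at which 2 of the 2 values shown sit.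

Whether a methoxy or an amine on this aromatic carbon would shift the number in the A2780 assay stays open; fluoro and hydrogen are the only pair shown here.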